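This account rests on a few compounds, and the source may have more. Where it says the series, first, only, none or still open, it means among the compounds named here.

Measured compounds:
compound 1 `NC1=NC2(CCSCC2)N(OCCCOc2cccc(Cl)c2Cl)C(N)=N1` — 89.8%
compound 2 `NC1=NC2(CCOCC2)N(OCCCOc2ccc(Br)cc2)C(N)=N1` — "not determined" (no result reported)

Within the data shown here, compound 1 is the only member of the series with a number in an assay on isolated protein for inhibition of Dihydrofolate reductase (Homo sapiens), read by spectrophotometry, using NADPH, with stated times of 5 s and 6 min, tested at 50 uM; on this read-out lower numbers stand for a weaker effect and higher numbers for a stronger effect at the one concentration tested; compound 2 has no result in this assay, so compound 1 stands alone at the top of the scale with nothing to rank it against. Compound 3 `NC1=NC2(CCSCC2)N(OCCCOc2cccc(Br)c2)C(N)=N1` differs from compound 1 in one place: 3-bromophenyl in place of 2,3-dichlorophenyl on an oxygen on a saturated carbon.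

Among the measured compounds shown here, no step between measured compounds is available, so no measured change of this kind guides the expectation for compound 3. Compound 1 gives 89.8% in this assay, close to the upper end of the read-out, which leaves little room for an upward move. The expected step of a number 4.8 percentage points lower from compound 1 to compound 3 (within the scatter) is therefore one within the usual scatter, downward if anything. Compound 3 is expected to give 85% in this assay, with a range from 68% to 95%.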

Compound 3, a percentage reported as inhibition, at one concentration (the size of the read-out at that concentration, not a potency): 86.5%
Estimate against measurement, compound 3: 1.5 percentage points below; the range from low to high includes it.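

In this assay, 3-bromophenyl in place of 2,3-dichlorophenyl on an oxygen on a saturated carbon gives a number 3.3 percentage points lower from compound 1 to compound 3 (within the scatter), so compound 1 and compound 3 cannot be told apart at this one concentration. This position therefore accepts more than the 2,3-dichlorophenyl group: a ring with a single bromine serves as well on this read-out, so the result does not depend on that exact halogen pattern. Nothing at hand bears on the reason for this result.

On these data alone, both aryl groups carry halogen, so it remains open whether a plain phenyl, or a phenyl bearing an amine or a carboxylic acid, would hold the read-out at this level. A percentage at one concentration also gives no potency, so any real difference between compound 1 and compound 3 stays hidden.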